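The source may hold more compounds than are shown below. What is called first, only, known or untested is meant among the compounds shown, and "the series" means these compounds.

Measured compounds:
Compound 1, `COc1ccccc1-c1ccc2ncn(-c3cc(OC)c(OC)c(OC)c3)c2c1`: 5050 nM
Compound 2, `COc1ccc(-c2ccc3ncn(-c4cc(OC)c(OC)c(OC)c4)c3c2)cc1O`: 44 nM
Compound 3, `COc1cc(-n2cnc3ccc(-c4cccc(N)c4)cc32)cc(OC)c1OC`: 21 nM

In a functional assay on SGC-7901 cells (Homo sapiens) for antiproliferative activity, read by MTT assay, with a stated time of 72 h (a higher number here means a weaker inhibitor, a lower number a stronger inhibitor), compound 1 gives the highest number of the three, so it is the weakest inhibitor here. Compound 4, `COc1cc(-n2cnc3ccc(-c4ccc(Cl)cc4Cl)cc32)cc(OC)c1OC`, differs from it by 2,4-dichlorophenyl in place of 2-methoxyphenyl on an aromatic carbon. The two measured steps that start from compound 1 are a 110-fold lower number from compound 1 to compound 2 (2.06 log units; beyond the scatter) and a 240-fold lower number from compound 1 to compound 3 (2.38 log units; beyond the scatter), both large gains; each replaces the 2-methoxyphenyl with a ring carrying a hydrogen-bond donor, whereas 2,4-dichlorophenyl carries 0 hydrogen-bond donors and 0 hydrogen-bond acceptors. Among the measured compounds shown here, no measured step covers such a change, so the expected step is small and uncertain: compound 4 is estimated to show a 2.0-fold lower number from compound 1 to compound 4 (0.31 log units; beyond the scatter), at 2500 nM, within 400 nM to 12000 nM.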

Compound 4, half-maximal inhibitory concentration: > 10000 nM
Compound 4: only a limit was reported; the forecaster's own chance of this, stated with the estimate: 10%; at least 4.0-fold (0.60 log units) between middle value and limit.
By their numbers in this assay, from the lowest: compound 3; then compound 2; then compound 1. At a limit, above all of these: compound 4.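

In this assay compound 4 gives > 10000 nM, which is a limit of the assay and not a number. Both rings that carry a hydrogen-bond donor stand far from 2,4-dichlorophenyl, which carries none: an at least 470-fold higher number from compound 3 to compound 4 (2.67 log units; beyond the scatter), and an at least 220-fold higher number from compound 2 to compound 4 (2.35 log units; beyond the scatter). Against 2-methoxyphenyl, also without a donor, the step is an at least 1.9-fold higher number from compound 1 to compound 4 (0.29 log units; that floor lies within the scatter), so no order between these two rings can be read.

The compounds shown leave open whether the missing donor or the chlorines matter here. An unsubstituted phenyl, a ring with a single chlorine or one with a carboxylic acid could help separate these.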